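A few compounds are considered here, and "the series" means these few. Any claim that something is new, unique, unknown or untested is made for them only; others in the source may bear on it.

The three measured compounds share one core and were read in an assay on HEK293 cells for inhibition of protein kinase C zeta type (Homo sapiens), read by 33P incorporation, with a stated time of 40 min, tested at 20 uM, in the presence of a further agent that is not named here; on this read-out lower numbers stand for less inhibition and higher numbers for more inhibition at the one concentration tested (going by the name of the read-out). Compound 1 `COc1ccc(C2=NN(c3ccc(Cl)cc3)C(c3ccc(Cl)cc3)C2)cc1` gives 23% in this assay. Among the compounds with values here, compound 2 `COc1ccc(C2=NN(c3ccc(Cl)cc3)C(c3cccc(Cl)c3)C2)cc1` gives 39% in this assay, and the only one-place step among the measured compounds is a number 16 percentage points higher from compound 1 to compound 2 (beyond the scatter). Compound 3 `COc1ccc(C2=NN(c3ccccc3Cl)C(c3ccccc3Cl)C2)cc1` gives 9.6% in this assay, the lowest of the three numbers; compound 1 stands nearest to it and compound 2 furthest, and both gaps lie beyond the scatter.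

Compound 4 `Nc1ccc(C2=NN(c3ccccc3Cl)C(c3ccccc3Cl)C2)cc1` differs from compound 3 in one place: amino in place of methoxy on an aromatic carbon. Within the data shown here, no measured step concerns this exchange. Among the measured compounds shown here, the single step available, a number 16 percentage points higher from compound 1 to compound 2 (beyond the scatter), is about the placement of a chlorophenyl group on the saturated ring carbon and offers nothing on the substituent of the methoxyphenyl ring. The account therefore rests on compound 3 alone, and with no precedent in either direction the expected step is a number 2.4 percentage points higher from compound 3 to compound 4 (within the scatter), a change not beyond the scatter. In this assay compound 4 is estimated to give 12%, with a range from 0% to 30% that is kept wide. The only anchor for that range is compound 3, which gives 9.6%.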

Compound 4, a percentage reported as inhibition, at one concentration (the size of the read-out at that concentration, not a potency): 31%
For compound 4 the middle estimate is 19 percentage points below the measured one; the measured number lies above the stated range.
By their numbers in this assay, from the lowest: compound 3; then compounds 1, 4 and 2 (each within the scatter of the next, the first and the last beyond it).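

In this assay, the change from 4-methoxyphenyl to 4-aminophenyl gives a number 21.4 percentage points higher from compound 3 to compound 4 (beyond the scatter), which shows that the read-out responds to the substituent at this position, on an aromatic carbon para to a large group. Within the data shown here, the only earlier step concerned a chlorophenyl group on a saturated ring carbon, so this is the first sign that the other end of the shared core also matters. The exchange removes methoxy, with 0 hydrogen-bond donors, and brings in amino, with 1 hydrogen-bond donor and a smaller heavy-atom count, but nothing at hand shows which of these differences accounts for the size of the step.

As far as these compounds go, this exchange can be read only on the core of compound 3, so it remains open whether amino would have a similar effect with the chlorophenyl arrangements of compound 1 or compound 2. From the compounds shown here alone, it also remains open how this position would read with a hydroxyl, a dimethylamino group, an acetamide or a carboxylic acid in place of amino.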